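Thioether variation on a shared purine riboside scaffold

The source may report more compounds than this note shows. Statements on the series, on what has been measured and on what is new or still open speak of the compounds shown alone.

Compound 1 `O=[N+]([O-])c1ccc(O)c(CSc2ncnc3c2ncn3[C@@H]2O[C@H](CO)[C@@H](O)[C@H]2O)c1`: 33.1 nM
Compound 2 `Nc1nc(SCc2ccc(F)cc2)c2ncn([C@@H]3O[C@H](CO)[C@@H](O)[C@H]3O)c2n1`: 1150 nM
Compound 3 `CCCC(C)n1cnc2c(SCc3ccccn3)nc(N)nc21`: 41700 nM

In an assay on isolated protein for binding affinity to Equilibrative nucleoside transporter 1 (Homo sapiens) (on this read-out lower numbers stand for stronger inhibition and higher numbers for weaker inhibition), compound 2 gives 1150 nM, the second highest of the three numbers. Compound 1 gives 33.1 nM, a considerably lower number that lies beyond the usual scatter, while compound 3 gives 41700 nM, a considerably higher one, also beyond the scatter. Compound 4 `CC(=O)c1ccccc1Sc1nc(N)nc2c1ncn2[C@@H]1O[C@H](CO)[C@@H](O)[C@H]1O` keeps the rest of the structure of compound 2 and differs in one place: 2-acetylphenyl in place of 4-fluorobenzyl on a sulfur. For the measured compounds named here, no pair of measured compounds isolates this change, so its effect in this assay can only be estimated. A modest shift toward a higher number is expected, not clearly beyond the scatter, giving an estimated step of a 1.7-fold higher number from compound 2 to compound 4 (0.24 log units; within the scatter). Compound 4 is therefore expected at about 2000 nM, within 400 nM to 10000 nM.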

Compound 4, half-maximal inhibitory concentration: 447000 nM
Compound 4: the middle estimate sits 220-fold (2.35 log units) below what was measured, and the stated range ends below it.
By their numbers in this assay, from the lowest: compound 1; then compound 2; then compound 3; then compound 4.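

On the sulfur of this core, the group matters greatly: in this assay, 2-acetylphenyl in place of 4-fluorobenzyl gives a 390-fold higher number from compound 2 to compound 4 (2.59 log units; beyond the scatter), a large loss of inhibition. Both groups carry one six-membered aromatic ring of carbon only, so keeping such a ring on the sulfur does not by itself preserve inhibition. Nothing measured here explains the size of this step. Going by these compounds, whether it follows from the acetyl group or from the change from benzyl to phenyl remains open. An unsubstituted phenyl or a benzyl bearing an acetyl on the same sulfur would separate the two.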